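The compounds below may be only part of what the source reports. "The series", "measured", "known", "first", "only" and "open" are said of these compounds alone.

Compound 1 `CC1CCN(c2c(S(=O)(=O)c3ccccc3)cnc3ccccc23)CC1` and compound 2 `COc1ccc(S(=O)(=O)c2cnc3ccc(C)cc3c2N2CCC(C)CC2)cc1Cl` share a core and differ in several places. In an assay on isolated protein for displacement of a labelled ligand from metabotropic glutamate receptor 5 (Homo sapiens), with a stated time of 60 min, tested at 1 uM (a lower number here means less inhibition, a higher number more inhibition at the concentration tested (going by the name of the read-out)), compound 1 gives 89.2%, and compound 2 gives 93%. Of these two numbers, compound 1 has the lower one, though the gap to compound 2 lies within the scatter, so the two cannot be ranked. Compound 3 `CCOC(=O)C1CCN(c2c(S(=O)(=O)c3ccccc3)cnc3ccccc23)CC1` has not yet been measured; it is derived from compound 1 by the change (ethoxycarbonyl in place of methyl on a saturated ring carbon). Among the compounds with values here, no measured pair shows this change, so any expectation rests on compound 1 alone. In this assay compound 3 is expected to give a high number of inhibition, with an estimated small step of a number 9.2 percentage points lower from compound 1 to compound 3 (within the scatter) that need not exceed the scatter. For compound 3 the estimated result is 80%, likely between 55% and 95%.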

Compound 3, a percentage reported as inhibition, at one concentration (the size of the read-out at that concentration, not a potency): 33%
Beside the measured number, compound 3's estimate is 47 percentage points above it; the measured number lies below the stated range.
By their numbers in this assay, from the lowest: compound 3; then compounds 1 and 2 (each within the scatter of the next).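

Ethoxycarbonyl in place of methyl on a saturated ring carbon gives a number 56.2 percentage points lower from compound 1 to compound 3 (beyond the scatter) in this assay. This shows that the group on this ring carbon, three ring bonds from the ring nitrogen, can strongly change the read-out, which compounds 1 and 2 could not show since both carry methyl there. Nothing measured here explains the drop. On these data alone, it remains open whether the drop is specific to ethoxycarbonyl, and what an ethyl chain, a carboxylic acid or an amine on this carbon would give.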